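A few compounds are considered here, and "the series" means these few. Any claim that something is new, unique, unknown or untested is made for them only; others in the source may bear on it.

Working notes on the arylpyrazole series carrying the homopiperazine group.

Going by the values given here, compound 1 `Cc1cccc(-c2n[nH]cc2N2CCCNCC2)c1` is one of three compounds measured in an assay on isolated protein for binding affinity to 5-hydroxytryptamine receptor 1D (Homo sapiens); a higher number here means a weaker inhibitor, a lower number a stronger inhibitor; compound 1 gives 3290 nM. Compound 2 `Cc1ccc(-c2n[nH]cc2N2CCCNCC2)cc1` gives 892 nM in this assay, and compound 3 `Fc1ccc(-c2n[nH]cc2N2CCCNCC2)cc1` gives 2190 nM. Compound 1 thus holds the highest number of the three: its gap to compound 3 is within the scatter, its gap to compound 2 is beyond it. Among the compounds with values here, the only step between measured compounds that differ in one place is a 2.5-fold higher number from compound 2 to compound 3 (0.39 log units; beyond the scatter).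

Compound 4 `COc1cccc(-c2n[nH]cc2N2CCCNCC2)c1` is not yet measured in this assay. It differs from compound 1 in one place: methoxy in place of methyl on an aromatic carbon. Within the data shown here, no measured step exchanges methyl for methoxy, and the step from compound 2 to compound 3 concerns a different group at a different place, so it bears on compound 4 only loosely. The change is expected to give no step beyond the scatter, a 1.1-fold lower number from compound 1 to compound 4 (0.04 log units; within the scatter). Compound 4 is therefore estimated at 3000 nM, with a range of 1200 nM to 8000 nM.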

Compound 4, inhibition constant: > 10000 nM
Compound 4: a limit, no number (the forecaster's own chance of this, stated with the estimate: 5%); middle value at least 3.3-fold (0.52 log units) away from the limit.
By their numbers in this assay, from the lowest: compound 2; then compounds 3 and 1 (each within the scatter of the next). At a limit, above all of these: compound 4.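

At this place, on an aromatic carbon meta to a large group, methyl and methoxy are not interchangeable in this assay: the exchange gives an at least 3.0-fold higher number from compound 1 to compound 4 (0.48 log units; beyond the scatter). Going by these compounds alone, this is the first step read at this place, since the only earlier step concerned fluoro in place of methyl on compound 2, and it shows that adding one oxygen to the group here is enough to move the number beyond the scatter. The result for compound 4 is a limit and not a number, so the step sets only a floor on the size of the change: the limit of > 10000 nM in this assay, at which 1 of the 4 values shown sits.

Going by these compounds, whether the step belongs to methoxy alone or extends to other groups at this place stays open; a hydroxyl, an amine or ethoxy there would bear on that. On these data alone, whether the same exchange on compound 2 gives a step of like size also stays open.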